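One Halogen Swap, Two Cores, One Expected Outcome

The compounds below may be only part of what the source reports. "The series", "measured", "known", "first", "only" and "open" are said of these compounds alone.

Compound 1 `Cc1c(C#N)c(-c2ccccc2)nn1CCCN1CCN(c2ccc(F)cc2)CC1` and compound 2 `Cc1c(C#N)c(-c2ccccc2)nn1CCCN1CCN(c2cccc(Cl)c2)CC1` share one core, while compound 3 `O=c1occ(-c2ccccc2)n1CCCN1CCN(c2ccc(F)cc2)CC1` and compound 4 `O=c1occ(-c2ccccc2)n1CCCN1CCN(c2cccc(Cl)c2)CC1` share another; how the two cores differ is not broken down here. In a functional assay on the whole organism (Abdomen, strain Swiss) for inhibition, with Mus musculus as the target, with stated times of 30 min, 10 min and 5 min, at a dose of 20 mg/kg by the oral route (a lower number here means a weaker effect, a higher number a stronger effect of the compound at the dose given), compound 1 gives 28% and compound 2 gives 0%. The change between them is 3-chlorophenyl in place of 4-fluorophenyl on an amine nitrogen in a ring, and it made a step of a number 28 percentage points lower from compound 1 to compound 2 (beyond the scatter). In this assay compound 3 gives 12%. Compound 4 carries the same change on its own core, (3-chlorophenyl in place of 4-fluorophenyl on an amine nitrogen in a ring), at a place described in identical words. Because compound 2 fell to 0%, compound 4 is expected to drop by a number 10 percentage points lower from compound 3 to compound 4 (within the scatter). The estimate for compound 4 in this assay is 2%, plausibly between 0% and 12%.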

Compound 4, a percentage reported as inhibition, in the whole organism at one dose (the size of the read-out at that dose, not a potency): 31%
The estimate for compound 4 lay 29 percentage points below the measured number; measured number outside the range, above it.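

In this assay, placing 3-chlorophenyl where 4-fluorophenyl stood gave a number 19 percentage points higher from compound 3 to compound 4 (beyond the scatter). The same change thus moved the two cores in opposite directions, by more than repeat measurements would explain: the same change on two cores in this assay, a number 28 percentage points lower (beyond the scatter) from compound 1 to compound 2 and a number 19 percentage points higher (beyond the scatter) from compound 3 to compound 4, 47 percentage points apart, beyond the scatter of two such steps. Going by these compounds alone, this shows that, for these two pairs, the result of the change on one core did not predict its result on the other, but it does not show why, and each core offers only a single pair tested at one dose.

Both the halogen and its ring position change together in these pairs. Compounds carrying 4-chlorophenyl or 3-fluorophenyl on each core could show which of the two matters, and whether the reversal extends beyond these four compounds.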